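This account rests on a few compounds, and the source may have more. Where it says the series, first, only, none or still open, it means among the compounds named here.

Compound 1 `CCc1nc(N)c2nc(O)n(Cc3ccccc3)c2n1` holds the lowest of the two numbers in a functional assay (spleen, spleen) for activation, with Mus musculus as the target; on this read-out lower numbers stand for an effect already at smaller amounts and higher numbers for an effect only at larger amounts of compound. In this assay compound 1 gives 1 uM. The nearest number belongs to compound 3 `Nc1ncnc2c1nc(S)n2Cc1ccccc1`, which in this assay gives 10 uM, a gap that lies beyond the scatter. Compound 2 `COc1nc2c(N)ncnc2n1Cc1ccccc1` is reported in this assay only as a limit of the assay and not as a number: the limit of > 10 uM in this assay, at which 1 of the 3 values shown sits. In this assay compound 2 gives > 10 uM. Among the measured compounds shown here, the one measured step, a number no higher from compound 2 to compound 3 (the limit leaves the size open), concerns sulfanyl in place of methoxy on an aromatic carbon and does not touch the change that leads to compound 4 `COc1nc(N)c2nc(O)n(Cc3ccccc3)c2n1`.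

Compound 4 differs from compound 1 in one place: methoxy in place of ethyl on an aromatic carbon. For the measured compounds named here, no measured step shows what methoxy in place of ethyl does at this position of the shared core, and compound 2, the only measured compound carrying a methoxy group, differs from compound 4 in more than one place. The expectation therefore leans on the value of compound 1, 1 uM, with wide room on either side. Compound 4 is expected to give about 3 uM in this assay, with a range of 0.7 uM to 10 uM. The step expected is a 3.0-fold higher number from compound 1 to compound 4 (0.48 log units; beyond the scatter), a change that may well stay within the scatter.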

Compound 4, minimum effective concentration: 0.1 uM
For compound 4 the middle estimate is 30-fold (1.48 log units) above the measured one; measured number outside the range, below it.
By their numbers in this assay, from the lowest: compound 4; then compound 1; then compound 3.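

The exchange of ethyl for methoxy on this aromatic carbon, between two ring nitrogen atoms, gives a 10-fold lower number from compound 1 to compound 4 (1.00 log units; beyond the scatter) in this assay. Among the compounds shown here, the earlier compounds held no measured step at this position of the shared core, so this is the first sign that the read-out responds to what sits there, even though the group that enters has the same count of heavy atoms as the one that leaves and differs from it by an oxygen in place of a carbon and by one hydrogen-bond acceptor. Nothing measured here bears on why this exchange acts as it does.

The compounds shown leave open whether a longer chain such as butoxy, or an amine such as methylamino, would hold the same place in the order or fall away from it, and so whether the oxygen itself or the whole methoxy group accounts for the step. They also leave open whether the step would keep its size on a different core.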